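This account rests on a few compounds, and the source may have more. Where it says the series, first, only, none or still open, it means among the compounds named here.

Compound 1 `C=C(C)CN(CC)Cc1c(C(F)(F)F)nc2n(-c3c(C)cc(C)cc3C)c(Cl)cn12` gives the lowest of the three numbers in an assay on cells for displacement of a labelled ligand from corticotropin-releasing factor receptor 1 (Homo sapiens), with a stated time of 100 min (on this read-out higher numbers stand for weaker inhibition and lower numbers for stronger inhibition), at 67 nM. Compound 2 `CCCN(Cc1ccc([N+](=O)[O-])cc1)Cc1c(C(F)(F)F)nc2n(-c3c(C)cc(C)cc3C)c(Cl)cn12` gives 150 nM in this assay, and compound 3 `CCN(Cc1ccc(Cl)c(Cl)c1)Cc1c(C(F)(F)F)nc2n(-c3c(C)cc(C)cc3C)c(Cl)cn12` gives 580 nM. Going by the values given here, the only single-point step, an 8.7-fold higher number from compound 1 to compound 3 (0.94 log units; beyond the scatter), bears on the change to compound 4 `Cc1cc(C)c(-n2c(Cl)cn3c(CN4CCC(c5ccccc5)C4)c(C(F)(F)F)nc23)c(C)c1`: 3-phenylpyrrolidin-1-yl in place of ethyl(2-methylprop-2-en-1-yl)amino on a saturated chain carbon bound to an aromatic carbon. Again a chain amine gives way to a group carrying an aromatic ring, and compound 2, which also carries an aromatic ring on its amine, sits above compound 1 without a single step linking them. A weakening step is therefore expected from compound 1 to compound 4, of about a 3.7-fold higher number from compound 1 to compound 4 (0.57 log units; beyond the scatter). For compound 4 the estimate in this assay is 250 nM, with an expected range from 80 nM to 800 nM.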

Compound 4, inhibition constant: 610 nM
Beside the measured number, compound 4's estimate is 2.4-fold (0.39 log units) below it; the measured number falls inside the stated range.
By their numbers in this assay, from the lowest: compound 1; then compound 2; then compounds 3 and 4 (each within the scatter of the next).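

In this assay, 3-phenylpyrrolidin-1-yl in place of ethyl(2-methylprop-2-en-1-yl)amino gives a 9.1-fold higher number from compound 1 to compound 4 (0.96 log units; beyond the scatter), so the weakening seen with an 8.7-fold higher number from compound 1 to compound 3 (0.94 log units; beyond the scatter) is not confined to open-chain amines: it also appears with a ring-closed amine carrying phenyl. No measurement here accounts for either step.

The new step combines ring closure with the added phenyl, and the compounds shown do not separate the two. Plain pyrrolidin-1-yl on the same saturated chain carbon would isolate the contribution of the ring.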